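Swapping Furan for Thiophene in an Oral Rat Assay

This account rests on a few compounds, and the source may have more. Where it says the series, first, only, none or still open, it means among the compounds named here.

Of the compounds shown here, three have been measured in a functional assay on the whole organism (plasma, strain Sprague-Dawley) with Rattus norvegicus as the target, with a stated time of 2 h, at a dose of 12.5 mg/kg by the oral route; a higher number here means a stronger effect of the compound at the dose given, a lower number a weaker effect. Compound 1 `c1ccc(C(/N=C2\CCCCCN2)c2ccco2)cc1` gives 5% in this assay. Compound 2 `c1ccc(C(/N=C2\CCCCCCN2)c2ccco2)cc1` gives 22% in this assay, and compound 3 `c1ccc(C(/N=C2\CCCCCN2)c2cccs2)cc1` gives 23% in this assay.

Compound 1 and compound 3 differ in one place. The change is thiophen-2-yl in place of furan-2-yl on a saturated chain carbon bound to an aromatic carbon and a double-bonded nitrogen and the step was a number 18 percentage points higher from compound 1 to compound 3 (beyond the scatter). Compound 1 and compound 2 carry different cores, and how those two cores differ is not broken down here; their two values show that compound 2 sits higher than compound 1, while compound 2 and compound 3 lie within the scatter of each other.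

Compound 4 `c1ccc(C(/N=C2\CCCCCCN2)c2cccs2)cc1` has not yet been measured. For the measured compounds named here, it is related to compound 2 by thiophen-2-yl in place of furan-2-yl on a saturated chain carbon bound to an aromatic carbon and a double-bonded nitrogen, which is the same change, at the same place, as the one between compound 1 and compound 3.

Going by the values given here, because the step of a number 18 percentage points higher from compound 1 to compound 3 (beyond the scatter) moved the number upward in this assay, a step of similar size is expected for the same change on the core of compound 2, with some allowance for the fact that only one earlier example exists. The step from compound 2 to compound 4 is thus estimated at a number 15 percentage points higher from compound 2 to compound 4 (beyond the scatter). For compound 4 the expected read-out in this assay is 37%, with a plausible range from 20% to 55%.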

Compound 4, a percentage reported as inhibition, in the whole organism at one dose (the size of the read-out at that dose, not a potency): 29%
The estimate for compound 4 lay 8 percentage points above the measured number; the measured number falls inside the stated range.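

Moved to the other core, the change from furan-2-yl to thiophen-2-yl gave a number 7 percentage points higher from compound 2 to compound 4 (within the scatter). For the compounds shown here, this step alone cannot be told apart from the ordinary spread of repeated results in this assay, unlike the earlier step on the first core, yet the two steps also cannot be told apart from each other: the same change on two cores in this assay, a number 18 percentage points higher (beyond the scatter) from compound 1 to compound 3 and a number 7 percentage points higher (within the scatter) from compound 2 to compound 4, 11 percentage points apart, within the scatter of two such steps So these four compounds give no sign that the core alters what this change does, but they do not prove that the change carries over in full either, as they offer only two pairs, one dose and one time point, and the second step on its own stays within the scatter.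

The compounds shown leave open how a six-membered aromatic group such as pyridin-2-yl, or a simple alkyl group such as methyl, would behave on a saturated chain carbon bound to an aromatic carbon and a double-bonded nitrogen. They also leave open whether the read-out would hold at other doses or times, since a single-dose percentage describes the size of an effect at that dose and is not a potency.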